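The source may hold more compounds than are shown below. What is called first, only, known or untested is meant among the compounds shown, and "the series" means these compounds.

Compound 1 `C[C@H](Oc1cccc(F)c1F)C(=O)Nc1ccc2oc(-c3ccc(F)cc3)nc2c1`, compound 2 `C[C@H](Oc1cccc(Cl)c1Cl)C(=O)Nc1ccc2oc(-c3ccc(F)cc3)nc2c1` and compound 3 `COc1ccc(-c2cn3cc(NC(=O)[C@H](C)Oc4cccc(Cl)c4Cl)ccc3n2)cc1` were tested in an assay on isolated protein for inhibition of GMP reductase 2 (Homo sapiens), read by spectrophotometry; a higher number here means a weaker inhibitor, a lower number a stronger inhibitor. For compound 1 the assay gives only a limit, > 5000 nM. For compound 2 it likewise gives only a limit, > 5000 nM. For compound 3 too the result is a limit, > 5000 nM. Among the measured compounds shown here, the single step between measured compounds, a step that the two limits leave unreadable from compound 1 to compound 2, cannot be sized, because both ends sit at the limit of > 5000 nM in this assay, at which 3 of the 3 values shown sit. Compound 2 thus stands at that limit, with no number to set it apart from the other two. Compound 4 `C[C@H](Oc1cccc(Cl)c1Cl)C(=O)Nc1ccc2oc(C3=CC=NCC3=O)nc2c1` differs from compound 2 by a group of 7 heavy atoms (5 carbon, 1 nitrogen, 1 oxygen; one six-membered non-aromatic ring with 1 hetero atom) in place of a group of 7 heavy atoms (6 carbon, 1 fluorine; one six-membered aromatic ring of carbon only), on an aromatic carbon. For the measured compounds named here, no measured step bears on this change. Compound 4 is therefore expected to remain weak, with an estimated step that the limit leaves unreadable from compound 2 to compound 4. Compound 4 is estimated at 8000 nM, with a range from 4000 nM to 30000 nM.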

Compound 4, inhibition constant: > 5000 nM
Compound 4 ended at the assay's limit (the forecaster's own chance of this, stated with the estimate: 85%); the middle value lies beyond the limit too.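

No new step can be read between compound 2 and compound 4, because both stand at a limit and not at a number: the limit of > 5000 nM in this assay, at which 4 of the 4 values shown sit. The compounds shown leave open which structural change would give a measurable inhibition constant in this assay.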